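The compounds below may be only part of what the source reports. "The series", "measured", "known", "first", "only" and "open" are said of these compounds alone.

Measured compounds:
Compound 1 `Cc1ccc(S(=O)(=O)N/C(=N\O)Nc2ccc(Cl)cc2)cc1`: 6 ug/mL
Compound 2 `Cc1c(S(=O)(=O)N/C(=N\O)Nc2ccc(Cl)cc2)sc2ccc(Cl)cc12`: 38 ug/mL
Compound 3 `Cc1ccc(S(=O)(=O)N/C(=N\O)Nc2ccc(Cl)c(Cl)c2)cc1`: 7 ug/mL

The three compounds were examined in a functional assay on MOLT-4 cells (Homo sapiens) for cytotoxicity; on this read-out lower numbers stand for stronger inhibition and higher numbers for weaker inhibition. Compound 1 and compound 3 share a core and differ in one place: chloro in place of hydrogen on an aromatic carbon. This change produced a 1.2-fold higher number from compound 1 to compound 3 (0.07 log units; within the scatter), so the two compounds cannot be ranked against each other on this read-out. Compound 2 carries a different core; how it differs from the core of compound 1 is not broken down here. Compound 2 gives the highest number of the three, and its gap to compound 3 and to compound 1 lies beyond the scatter in each case.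

Compound 4 `Cc1c(S(=O)(=O)N/C(=N\O)Nc2ccc(Cl)c(Cl)c2)sc2ccc(Cl)cc12` has not yet been measured. It arises from compound 2 by the same change that leads from compound 1 to compound 3: chloro in place of hydrogen on an aromatic carbon. Because a 1.2-fold higher number from compound 1 to compound 3 (0.07 log units; within the scatter) was within the scatter, the step from compound 2 to compound 4 is expected to be small as well, estimated as a 1.1-fold higher number from compound 2 to compound 4 (0.04 log units; within the scatter). On this basis compound 4 is expected to give about 42 ug/mL in this assay, with a likely range from 18 ug/mL to 95 ug/mL.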

Compound 4, half-maximal inhibitory concentration: > 300 ug/mL
Compound 4: a limit, no number; the forecaster's own chance of this, stated with the estimate: 5%; middle value at least 7.1-fold (0.85 log units) from the limit.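

In this assay compound 4 gives > 300 ug/mL, which is a limit of the assay and not a number. Chloro in place of hydrogen on an aromatic carbon, the change from 4-chlorophenyl to 3,4-dichlorophenyl, gave an at least 7.8-fold higher number from compound 2 to compound 4 (0.89 log units; beyond the scatter), while on the other core it gave a 1.2-fold higher number from compound 1 to compound 3 (0.07 log units; within the scatter), so in this series the size of the step did not carry over from one core to the other: the same change on two cores in this assay, a 1.2-fold higher number (0.07 log units; within the scatter) from compound 1 to compound 3 and an at least 7.8-fold higher number (0.89 log units; beyond the scatter) from compound 2 to compound 4, at least 6.7-fold (0.83 log units) apart, beyond the scatter of two such steps This rests on a single pair of compounds for each core, and since one end of the new step is a limit, the data give only a lower bound on its size and do not show why the two cores part ways.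

On these data alone, it remains open whether the same change would stay small or grow large on any further core. Also open, as far as these compounds go, is whether fluoro, methoxy or an amine on that aromatic carbon would follow chloro on either core.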